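A few compounds are considered here, and "the series" means these few. Any claim that something is new, unique, unknown or untested is made for them only; others in the source may bear on it.

Compound 3 `N[C@@H](COP(=O)(O)OC[C@H]1OCCC[C@H]1OC(=O)CCc1ccccc1OCc1cccc(Oc2ccccc2)c1)C(=O)O` is one of three closely related compounds measured in an assay on HEK293-A cells with probable G-protein coupled receptor 34 (Mus musculus) as the target, with a stated time of 1.5 h; a higher number here means a larger maximal response, a lower number a smaller maximal response. In this assay compound 3 gives 0.85, the lowest of the two numbers reported. For the measured compounds named here, compound 2 `Cc1ccc(Oc2cccc(COc3ccccc3CCC(=O)O[C@@H]3CCCO[C@@H]3COP(=O)(O)OC[C@H](N)C(=O)O)c2)cc1` gives 1.9 in this assay, and the step a number 1.1 lower from compound 2 to compound 3 (beyond the scatter) is the only measured step with a number. Going by the values given here, compound 1 `N[C@@H](COP(=O)(O)OC[C@H]1OCCC[C@@H]1OC(=O)CCc1ccccc1OCc1cccc(Oc2ccccc2)c1)C(=O)O` is reported in this assay as "not active" (no number reported); it differs from compound 3 at one place, and the fact that one of compounds 1 and 3 is drawn with a defined configuration and the other without, at the place where they differ is what the drawings show there, so no counted step stands between them.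

Compound 4 `N[C@@H](COP(=O)(O)OC[C@H]1OCCC[C@H]1OC(=O)CCc1ccccc1OCc1cccc(Oc2ccc(Cl)cc2)c1)C(=O)O` has not yet been measured. It differs from compound 3 by chloro in place of hydrogen on an aromatic carbon. The step that bears on this is a number 1.1 lower from compound 2 to compound 3 (beyond the scatter), which shows that replacing methyl by hydrogen on an aromatic carbon lowered the response by a large amount, beyond the scatter. Putting a chloro group onto an aromatic carbon is a change in the opposite sense, so the expected step a number 0.75 higher from compound 3 to compound 4 (beyond the scatter) is upward and beyond the scatter, though compound 2 and compound 3 alone cannot fix its size exactly. Compound 4 is therefore expected to give 1.6 in this assay, between 1 and 2.2.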

Compound 4, intrinsic activity: the largest response reached, as a fraction of the reference agonist's: 1.2
The estimate for compound 4 lay 0.40 above the measured number; low and high end bracket the measured number.
By their numbers in this assay, from the lowest: compound 3; then compound 4; then compound 2.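

Before this result, the only group seen on this aromatic carbon, para to a large group, was the methyl of compound 2, so it could not be said whether the higher response belonged to methyl alone. Chloro on the same carbon also raises the maximal response in this assay with a number 0.35 higher from compound 3 to compound 4 (beyond the scatter) and so, among these compounds, hydrogen gives the lowest number, and two different groups at this place both give a higher one. The two groups are not interchangeable, however, as the comparison of chloro with methyl in this assay shows a number 0.70 lower from compound 2 to compound 4 (beyond the scatter) and this means that the identity of the group on this carbon matters, and not only the loss of the hydrogen.

The compounds shown leave open how a fluoro group, a methoxy group, an amine or a carboxylic acid on this carbon would compare, and whether chloro on another carbon of the same ring would give a similar rise. Nothing available here bears on why chloro and methyl differ at this place.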